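Changing the amine side chain of compound 2

The compounds below may be only part of what the source reports. "The series", "measured", "known", "first", "only" and "open" are said of these compounds alone.

In a functional assay on NCI-H460 cells (Homo sapiens) for antiproliferative activity, read by MTT assay, with a stated time of 72 h (on this read-out lower numbers stand for stronger inhibition and higher numbers for weaker inhibition), compound 2 (`CCN(CC)CCn1cnnc1-c1cc(Oc2ccc(NC(=O)Nc3ccc(F)c(Cl)c3)cc2F)ccn1`) gives 7390 nM, and compound 3 (`CCN(CC)CCn1cnnc1-c1cc(Oc2ccc(NC(=O)Nc3ccc(Cl)cc3Cl)cc2F)ccn1`) gives 5380 nM. The gap between them, a 1.4-fold lower number from compound 2 to compound 3 (0.14 log units; within the scatter), lies within the scatter, so compound 2 shares the measurable range with compound 3. Compound 1 (`CCN(CC)CCn1cnnc1-c1cc(Oc2ccc(NC(=O)Nc3ccccc3C(F)(F)F)cc2F)ccn1`) reaches only a limit of the assay, > 50000 nM.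

Compound 4 (`CN(C)CCCn1cnnc1-c1cc(Oc2ccc(NC(=O)Nc3ccc(F)c(Cl)c3)cc2F)ccn1`) departs from compound 2 in the side chain alone: (dimethylamino)methyl in place of diethylamino on a saturated chain carbon, two bonds along the chain from an aromatic nitrogen. This places (dimethylamino)methyl in place of diethylamino on a saturated chain carbon, two bonds along the chain from an aromatic nitrogen. Cut one bond further out, 2-(diethylamino)ethyl becomes 3-(dimethylamino)propyl.

The measured steps all concern the aryl group on an amide-type nitrogen, and none touches this chain. Both an at least 6.7-fold lower number from compound 1 to compound 2 (0.83 log units; beyond the scatter) and an at least 9.2-fold lower number from compound 1 to compound 3 (0.96 log units; beyond the scatter) lie beyond the scatter, yet they change a different part of the molecule and give no direct measure for this one. The estimate therefore rests on compound 2 at 7390 nM. The expected change, a 1.1-fold lower number from compound 2 to compound 4 (0.02 log units; within the scatter), is no step beyond the scatter in this assay, although the lack of any measured chain change keeps the range wide. For compound 4 the estimated value is 7000 nM, with an expected range from 2500 nM to 20000 nM.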

Compound 4, half-maximal inhibitory concentration: 1270 nM
Compound 4: the middle estimate sits 5.5-fold (0.74 log units) above what was measured; the whole stated range lies above it.
By their numbers in this assay, from the lowest: compound 4; then compounds 3 and 2 (each within the scatter of the next). At a limit, above all of these: compound 1.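

In this assay the side chain proves to be a place where the number moves: a 5.8-fold lower number from compound 2 to compound 4 (0.76 log units; beyond the scatter), with the 3-chloro-4-fluorophenyl group on the amide-type nitrogen left as it was. Going by these compounds alone, the earlier steps all changed that aryl group, so this is the first measured step on the chain, and it shows that replacing 2-(diethylamino)ethyl with 3-(dimethylamino)propyl on the aromatic nitrogen is enough to go beyond the scatter. Nothing among the data shown accounts for the size or direction of this step.

On these data alone, the change alters the groups on the amine and the length of the chain at once, so it stays open which of the two carries the step, a question that a 3-(diethylamino)propyl group or a 2-(dimethylamino)ethyl group would separate. Also open, as far as these compounds go, are whether a cyclic amine such as morpholine or a longer chain such as 4-(dimethylamino)butyl would move the number further, and whether 3-(dimethylamino)propyl gives a similar step alongside the 2,4-dichlorophenyl group of compound 3.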